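The compounds below may be only part of what the source reports. "The series", "measured", "known", "first", "only" and "open" are said of these compounds alone.

Measured so far:
Compound 1, `CCOC(=O)/C=C/c1ccc(OC)c(OC(=O)c2nc(C)c(C)nc2C)c1` — 117%
Compound 2, `Cc1nc(C)c(C(=O)Oc2cccc(/C=C/C(=O)O)c2)nc1C` — 103%

Both compounds were tested in a functional assay on EA.hy 926 cells (Homo sapiens) for cytotoxicity, read by MTT assay, with stated times of 24 h and 12 h, tested at 100 uM; a lower number here means a weaker effect, a higher number a stronger effect of the compound at the concentration tested. Compound 1 gives 117% in this assay. Within the data shown here, compound 2 gives 103%, the lower of the two numbers, and the gap to compound 1, its only neighbour here, lies beyond the scatter of repeated measurements. The two structures differ in more than one place, so the data show only where each stands, not what any single change does.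

Compound 3, `CCOC(=O)/C=C/c1cccc(OC(=O)c2nc(C)c(C)nc2C)c1`, has not been measured yet. It differs from compound 2 in exactly one place: ethyl in place of hydrogen on an oxygen next to a carbonyl group. This is the same ester that compound 1 carries, while the rest of compound 3 follows compound 2. Among the measured compounds shown here, with no single-change step between measured compounds available, the direction of this change has to be guessed from where compound 1 and compound 2 stand.

The step of a number 7 percentage points higher from compound 2 to compound 3 (within the scatter) is expected to be upward and small, possibly not beyond the scatter. Compound 3 is therefore estimated to give about 110%, with a likely range from 96% to 124%.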

Compound 3, a percentage reported as activity, at one concentration (the size of the read-out at that concentration, not a potency): 47%
The estimate for compound 3 lay 63 percentage points above the measured number, and the stated range ends above it.
By their numbers in this assay, from the lowest: compound 3; then compound 2; then compound 1.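

Ethyl in place of hydrogen on an oxygen next to a carbonyl group gives a number 56 percentage points lower from compound 2 to compound 3 (beyond the scatter) in this assay, so this one change, turning carboxy into ethoxycarbonyl, is enough on its own to move the read-out by a large amount. The second single change, hydrogen in place of methoxy on an aromatic carbon, gives a number 70 percentage points lower from compound 1 to compound 3 (beyond the scatter) in the same assay, which means the number also depends strongly on a place far from the ester, and compound 3, which keeps the ester but lacks the methoxy, stands lowest of the three. Nothing available here explains why either step is so large.

The compounds shown leave open whether a longer chain such as propyl on that oxygen, or an amide in place of the ester, would behave like ethyl or like hydrogen. They also leave open whether another group on the aromatic carbon, such as ethoxy or chlorine, would act as methoxy does, and whether the ethyl step would be equally large with methoxy present.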